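The compounds below may be only part of what the source reports. "The series", "measured", "known", "first", "only" and "open" are said of these compounds alone.

Measured so far:
compound 1 `CCOC(=O)C1=C(C[Se]C(=O)c2ccc(C)cc2)NC(=O)NC1c1cccc([N+](=O)[O-])c1` — 24500 nM
compound 2 `CCOC(=O)C1=C(C[Se]C(=O)c2ccc(C)cc2)NC(=O)NC1c1ccc(O)c(OC)c1` — 8100 nM

In a physicochemical assay, read by spectrophotometry, with a stated time of 10 min (a lower number here means that less compound is needed, a higher number that more compound is needed for the effect), compound 1 stands at the highest of the two numbers; its nearest neighbour, compound 2, lies at 8100 nM. Among the measured compounds shown here, the only step measured so far is a 3.0-fold lower number from compound 1 to compound 2 (0.48 log units; beyond the scatter), a swap of the whole aryl group on the saturated ring carbon.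

Compound 3 `CCOC(=O)C1=C(C[Se]C(=O)c2ccc(C)cc2)NC(=O)NC1c1ccccc1` is not yet measured. It differs from compound 1 by hydrogen in place of nitro on an aromatic carbon, so the aryl group is kept and only the nitro is taken away. For the measured compounds named here, the step from compound 1 to compound 2 bears on this only loosely: it exchanges the 3-nitrophenyl for a different substituted phenyl rather than stripping it bare, and it is the sole point of comparison. Given that the nitro-bearing compound 1 gives the highest number, a modest drop is expected, though the size is uncertain. For compound 3 the step is estimated at a 1.6-fold lower number from compound 1 to compound 3 (0.21 log units; within the scatter). Compound 3 is thus expected to give 15000 nM, within 6000 nM to 40000 nM.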

Compound 3, half-maximal effective concentration: 10500 nM
Estimate against measurement, compound 3: 1.4-fold (0.15 log units) above, and the stated range covers the measured number.
By their numbers in this assay, from the lowest: compounds 2 and 3 (each within the scatter of the next); then compound 1.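

In this assay, taking the nitro away while keeping the aryl group gives a 2.3-fold lower number from compound 1 to compound 3 (0.37 log units; beyond the scatter), so the nitro alone is enough to separate compound 1 from compound 3, and exchanging the whole aryl group is not needed for a step beyond the scatter. The bare phenyl and the 4-hydroxy-3-methoxyphenyl give a 1.3-fold higher number from compound 2 to compound 3 (0.11 log units; within the scatter), so the hydroxy and methoxy groups of compound 2 bring no readable difference over hydrogen in this series. No evidence on hand accounts for either step.

On these data alone, whether an amine or a nitrile on the same aromatic carbon would stay with compound 1 or with compound 3 remains open. Also open, as far as these compounds go, is how the number responds elsewhere on the core, for example to a carboxylic acid in place of the ethyl ester.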